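Swapping the Imidazole for a Thiadiazole on the Amide

The source may hold more compounds than are shown below. What is called first, only, known or untested is meant among the compounds shown, and "the series" means these compounds.

Going by the values given here, compound 2 `CC(C)[C@H](C(=O)Nc1ncc[nH]1)c1ccc(Cl)cc1` gives 55% in a functional assay on CHO cells for agonist activity at Free fatty acid receptor 2 (Homo sapiens), read by cAMP accumulation (on this read-out higher numbers stand for larger maximal responses and lower numbers for smaller maximal responses), the lower of the two numbers known, while compound 1 `CC(C)[C@H](C(=O)Nc1ccccn1)c1ccc(Cl)cc1` gives 92%. Among the compounds with values here, the only measured step, a number 37 percentage points lower from compound 1 to compound 2 (beyond the scatter), shows that the ring on the amide-type nitrogen matters a great deal. Compound 3 `CC(C)[C@H](C(=O)Nc1cnns1)c1ccc(Cl)cc1` differs from compound 2 by 1,2,3-thiadiazol-5-yl in place of 1H-imidazol-2-yl on an amide-type nitrogen. Within the data shown here, no measured pair mirrors this change, so the expectation is loose: compound 3 is estimated to land at 70%, between 40% and 95%. That corresponds to an expected upward step of a number 15 percentage points higher from compound 2 to compound 3 (beyond the scatter).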

Compound 3, largest response reached (reported as efficacy), in percent of the reference or control that the assay uses: 48%
The estimate for compound 3 lay 22 percentage points above the measured number; the measured number falls inside the stated range.
By their numbers in this assay, from the lowest: compounds 3 and 2 (each within the scatter of the next); then compound 1.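

In this assay, the step of a number 7 percentage points lower from compound 2 to compound 3 (within the scatter) shows that the position on the amide-type nitrogen tolerates 1,2,3-thiadiazol-5-yl and 1H-imidazol-2-yl alike, although only the latter carries a hydrogen-bond donor. The step of a number 44 percentage points lower from compound 1 to compound 3 (beyond the scatter) is a large loss of the same kind as that seen with 1H-imidazol-2-yl, so that of the three rings only pyridin-2-yl holds the larger response. Going by these compounds, whether a plain phenyl on this nitrogen, or an amine on the pyridin-2-yl ring, would hold that response stays open. No evidence at hand explains why these rings differ.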